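Working notes: the step from compound 3 to compound 4

This account rests on a few compounds, and the source may have more. Where it says the series, first, only, none or still open, it means among the compounds named here.

Measured so far in an ADME assay on CHO cells (Cricetulus griseus) for cytotoxicity, read by LDH release; on this read-out higher numbers stand for weaker inhibition and lower numbers for stronger inhibition
Compound 1 `CC(Cc1ccc(Cl)cc1Cl)C(=O)NCc1ccc(F)cc1` has "not determined" (no result reported)
Compound 2 `CC(Oc1ccc(Cl)cc1Cl)C(=O)NC1(c2ccc(F)cc2)CC1` gives 28000 nM
Compound 3 `CC(Oc1ccc(Cl)cc1Cl)C(=O)NC(c1ccc(F)cc1)C1CC1` gives > 100000 nM as a limit

Compound 3 stands on a limit and not on a number (> 100000 nM), the only such case in the set (the limit of > 100000 nM in this assay, at which 1 of the 3 values shown sits).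

Compound 4 `COC(=O)C(NC(=O)C(C)Oc1ccc(Cl)cc1Cl)c1ccc(F)cc1` carries methoxycarbonyl in place of cyclopropyl on a saturated chain carbon bound to an amide-type nitrogen and an aromatic carbon. Going by the values given here, no measured step between compounds that differ in one place is available to size this change. An estimated step (an at least 1.4-fold lower number from compound 3 to compound 4 (0.15 log units; that floor lies within the scatter)) of moderate size toward stronger inhibition is expected in this assay. Among the compounds with values here, the expectation leans on compound 2 (28000 nM), the only number so far, and the low end of the range is set near it. For compound 4 a reading that gives only a limit is nearly as likely as a number. For compound 4 the expected value is 70000 nM (estimated range 30000 nM to 150000 nM).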

Compound 4, half-maximal inhibitory concentration: > 100000 nM
Compound 4 was reported as a limit; the forecaster's own chance of this, stated with the estimate: 45%; middle value at least 1.4-fold (0.15 log units) away from the limit.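

Compound 3 and compound 4 both stand on a limit and not on a number, so no step can be read between them: the limit of > 100000 nM in this assay, at which 2 of the 4 values shown sit.

The compounds shown leave open whether methoxycarbonyl and cyclopropyl at this place differ at all in this assay.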